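Aryl group exchange on the shared core: compound 3

The compounds below may be only part of what the source reports. "The series", "measured", "known", "first", "only" and "open" are said of these compounds alone.

Within the data shown here, compound 2 `O=[N+]([O-])c1cc2c(OCCC3CCCCN3)c(-c3cccc(Cl)c3)c(O)nc2cc1Cl` gives 40 nM in a functional assay on cells (Pituitary gland cell) for antagonist activity at Gonadotropin-releasing hormone receptor (Rattus norvegicus) (a higher number here means a weaker inhibitor, a lower number a stronger inhibitor), the lowest of the two numbers measured so far; the nearest is compound 1 `COc1ccc(-c2c(O)nc3cc(Cl)c([N+](=O)[O-])cc3c2OCCC2CCCCN2)cc1OC`, which in this assay gives 600 nM. Among the measured compounds shown here, the one measured step, a 15-fold lower number from compound 1 to compound 2 (1.18 log units; beyond the scatter), came with 3-chlorophenyl in place of 3,4-dimethoxyphenyl on an aromatic carbon. Compound 3 `Cc1ccc(-c2c(O)nc3cc(Cl)c([N+](=O)[O-])cc3c2OCCC2CCCCN2)c(C)c1` is not yet measured. It differs from compound 2 by 2,4-dimethylphenyl in place of 3-chlorophenyl on an aromatic carbon. For the measured compounds named here, no measured step covers this exchange directly; the step from compound 1 to compound 2 shows only that the group on this aromatic carbon moves the number by a large amount, with 3-chlorophenyl giving the lower value of the two. A 2,4-dimethylphenyl is neither of the two groups seen so far, so the direction cannot be read from one step alone. The number for compound 3 is expected to fall between the two measured values. For compound 3 the expected change is therefore a 3.8-fold higher number from compound 2 to compound 3 (0.57 log units; beyond the scatter). The estimate for compound 3 in this assay is 150 nM, in the range 40 nM to 600 nM.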

Compound 3, half-maximal inhibitory concentration: 400 nM
The estimate for compound 3 lay 2.7-fold (0.43 log units) below the measured number, within the range that was stated.
By their numbers in this assay, from the lowest: compound 2; then compounds 3 and 1 (each within the scatter of the next).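

In this assay the step of a 10-fold higher number from compound 2 to compound 3 (1.00 log units; beyond the scatter) shows that replacing the 3,4-dimethoxyphenyl group does not by itself give a low number at this aromatic carbon. The step of a 1.5-fold lower number from compound 1 to compound 3 (0.18 log units; within the scatter) places the 2,4-dimethylphenyl and 3,4-dimethoxyphenyl groups together, so among the three aryl groups shown, only 3-chlorophenyl stands apart. No measurement at hand bears on the reason for this gap.

The compounds shown leave open whether the chlorine itself or the aryl group as a whole goes with the low number; a fluorine or a methyl group in place of that chlorine, or a bare phenyl, would separate the two. Also open, going by these compounds, is whether the gap between the 3-chlorophenyl and 2,4-dimethylphenyl groups persists when the 2-(piperidin-2-yl)ethoxy group is exchanged for a longer chain or for another amine.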